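A few compounds are considered here, and "the series" means these few. Any claim that something is new, unique, unknown or untested is made for them only; others in the source may bear on it.

Measured so far:
- compound 1, `CCCc1nc(-c2ccccc2)c(CNCCN2CCN(c3ccccc3Cl)CC2)o1`: 60.1%
- compound 2, `CCCc1nc(-c2ccccc2)c(CNCCN2CCN(C(c3ccccc3)c3ccccc3)CC2)o1`: 71.9%
- compound 3, `CCCc1nc(-c2ccccc2)c(CNCCCN2CCN(c3ccccc3OC)CC2)o1`: 41%

Three compounds with the shared core carry different groups on the distal piperazine nitrogen, and all were run in an assay on HEK293 cells for inhibition of Voltage-dependent T-type calcium channel subunit alpha-1G (Homo sapiens), read by fluorescence, tested at 10 uM; on this read-out higher numbers stand for more inhibition at the one concentration tested (going by the name of the read-out) and lower numbers for less inhibition. Compound 2 gives 71.9%, compound 1 gives 60.1%, and compound 3, which also has the longer linker, gives 41%. Compound 1 thus stands second of the three; compound 2 lies above it by a margin beyond the scatter, and compound 3 lies below it by a wider margin, also beyond the scatter. For the measured compounds named here, no pair of these differs in a single place, so none of these gaps can be read as a clean step.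

Compound 4, `CCCc1nc(-c2ccccc2)c(CNCCN2CCN(c3ccccc3)CC2)o1`, has not been measured. It differs from compound 1 by hydrogen in place of chloro on an aromatic carbon. Going by the values given here, the change is small in size, and no measured pair here shows what removing that one group does; the nearest guide is that compound 1 and compound 3, with different aryl substitution and linker length, fall on either side of the middle of the range. A modest drop is expected, of a size a number 8.1 percentage points lower from compound 1 to compound 4 (within the scatter), which may or may not clear the scatter.

For compound 4 the expected inhibition in this assay is 52%, with a range from 32% to 70%.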

Compound 4, a percentage reported as inhibition, at one concentration (the size of the read-out at that concentration, not a potency): 54.3%
Estimate against measurement, compound 4: 2.3 percentage points below; the range from low to high includes it.
By their numbers in this assay, from the lowest: compound 3; then compounds 4 and 1 (each within the scatter of the next); then compound 2.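

In this assay, for the compounds shown here, the exchange of 2-chlorophenyl for phenyl gives the first step that can be read at a single place: a number 5.8 percentage points lower from compound 1 to compound 4 (within the scatter). At this position, on an aromatic carbon ortho to a large group, chloro and hydrogen therefore cannot be told apart at the one concentration tested, so the chloro is not shown to be needed for the inhibition seen with compound 1. No supporting measurement is available to explain this outcome or to assign any property to the chloro group.

Still open, as far as these compounds go, is whether a larger or differently charged group on the same aromatic carbon, such as a trifluoromethyl, an amine or a carboxylic acid, would give a step beyond the scatter, as chloro and hydrogen alone span only a small change. Going by these compounds alone, the effect of the longer chain also remains open, since compound 3 differs from compound 1 in more than one place and no single-place step isolates it.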